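Swapping the amide amine on a pyrimidinone side chain

A few compounds are considered here, and "the series" means these few. Any claim that something is new, unique, unknown or untested is made for them only; others in the source may bear on it.

Measured compounds:
- compound 1 `CCCCCCCCN(C)C(=O)Cn1cc(Cc2cnc(=O)n(C)c2)c(=O)nc1SCc1ccc(F)cc1`: 19%
- compound 2 `CCCCCCCCN(C)C(=O)Cn1cc(Cc2cnc(=O)n(CCO)c2)c(=O)nc1SCc1ccc(F)cc1`: 36%
- compound 3 `CCCCCCCCN(C)C(=O)Cn1cc(Cc2cnc(=O)n(CC(=O)NCCC)c2)c(=O)nc1SCc1ccc(F)cc1`: 16%

In a functional assay on a cell-free system (plasma, Oryctolagus cuniculus) for inhibition of platelet-activating factor acetylhydrolase (Homo sapiens), tested at 100 nM (a higher number here means more inhibition at the concentration tested (going by the name of the read-out), a lower number less inhibition), compound 3 gives 16%. Against compound 1 it sits a number 3 percentage points lower from compound 1 to compound 3 (within the scatter), and against compound 2 it sits a number 20 percentage points lower from compound 2 to compound 3 (beyond the scatter). For the measured compounds named here, the only change among the measured compounds that went beyond the scatter was a number 17 percentage points higher from compound 1 to compound 2 (beyond the scatter).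

Compound 4 `CCCCCCCCN(C)C(=O)Cn1cc(Cc2cnc(=O)n(CC(=O)N3CCN(C)CC3)c2)c(=O)nc1SCc1ccc(F)cc1` is not yet measured. It differs from compound 3 in one place: 4-methylpiperazin-1-yl in place of propylamino on a carbonyl carbon. Going by the values given here, none of the measured steps touches this part of the molecule; they all exchange the whole group on the saturated chain carbon bound to the aromatic nitrogen, whereas here the propylcarbamoyl is kept and only its amine half is exchanged. Among the compounds with values here, there is thus no step of the same kind to lean on. The expectation for compound 4 is therefore a change of about a number 4 percentage points higher from compound 3 to compound 4 (within the scatter), that is, nothing clearly beyond the scatter, with a wide range. Compound 4 is estimated at 20%, between 5% and 40%.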

Compound 4, a percentage reported as inhibition, at one concentration (the size of the read-out at that concentration, not a potency): 40%
Estimate against measurement, compound 4: 20 percentage points below; the measured number falls inside the stated range.
By their numbers in this assay, from the lowest: compounds 3 and 1 (each within the scatter of the next); then compounds 2 and 4 (each within the scatter of the next).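

With the carbonyl kept, the amine half of this amide turns out to matter in this assay: 4-methylpiperazin-1-yl in place of propylamino gives a number 24 percentage points higher from compound 3 to compound 4 (beyond the scatter). The (4-methylpiperazin-1-yl)carbonyl group also compares well with the simplest group at this place, with a number 21 percentage points higher from compound 1 to compound 4 (beyond the scatter), and it matches hydroxymethyl, with a number 4 percentage points higher from compound 2 to compound 4 (within the scatter), so an amide at this position can do as well as that smaller group. No measurement shown here explains why the amine exchange has this effect.

The exchange changes several things at once: it adds a ring and a second nitrogen and removes the amide hydrogen, so the compounds shown do not say which of these matters. A piperidine amide, a morpholine amide or an N-methyl-N-propyl amide would begin to separate these changes.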